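The source may hold more compounds than are shown below. What is called first, only, known or untested is meant among the compounds shown, and "the series" means these compounds.

In a physicochemical assay for solubility, using the shake flask method, measured as kinetic solubility, with a stated time of 2 h, at pH 7.4 (on this read-out higher numbers stand for higher solubility and lower numbers for lower solubility), the series so far reads as follows

Compound 1 `CN(c1ccccc1)c1cc(C(=O)Nc2ccccc2)ncn1` gives < 5000 nM (a limit)
Compound 2 `CN(Cc1ccc(F)cc1)c1cc(C(=O)Nc2ccccc2)ncn1` gives < 5000 nM (a limit)
Compound 3 `CN(Cc1ccc(S(C)(=O)=O)cc1)c1cc(C(=O)Nc2ccccc2)ncn1` gives 10000 nM (a number)

Compound 2 has no number of its own, only the limit of < 5000 nM in this assay, at which 2 of the 3 values shown sit, in this short series. Compound 4 `Cc1csc(NC(=O)c2cc(N(C)Cc3ccc(F)cc3)ncn2)n1` carries 4-methyl-1,3-thiazol-2-yl in place of phenyl on an amide-type nitrogen. Among the measured compounds shown here, no measured step touches that place. The two measured steps lie elsewhere in the structure: a step that the two limits leave unreadable from compound 1 to compound 2 gives no size, and an at least 2.0-fold higher number from compound 2 to compound 3 (0.30 log units; that floor lies within the scatter) comes with methylsulfonyl in place of fluoro on an aromatic carbon and has a floor within the scatter. With nothing measured at the amide-type nitrogen, no step beyond the scatter is expected in this assay in either direction. The step expected is a step that the limit leaves unreadable from compound 2 to compound 4 as a working estimate. For compound 4 the estimated value is 3500 nM and the expected range runs from 1000 nM to 10000 nM on present data, with a reading that is only a limit quite likely.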

Compound 4, solubility: < 5000 nM
Compound 4: no number, only a limit; the forecaster's own chance of this, stated with the estimate: 65%; the middle value lies beyond the limit too.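

In this assay compound 4 gives < 5000 nM, which is a limit. Compound 2 also has only a limit, so no step can be read between compound 2 and compound 4: the limit of < 5000 nM in this assay, at which 3 of the 4 values shown sit.

From the compounds shown here alone, the size and direction of any effect of 4-methyl-1,3-thiazol-2-yl in place of phenyl on an amide-type nitrogen remain open.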